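A few compounds are considered here, and "the series" means these few. Any claim that something is new, unique, unknown or untested is made for them only; others in the source may bear on it.

Compound 1, `COc1ccc(-n2c(-c3ccccc3)cc3c2CCCC3)cc1C(=O)O`: 40%
Compound 2, `COc1ccccc1-c1cc2c(n1-c1ccc(O)c(C(=O)O)c1)CCCC2`: 50%

In a functional assay on the whole organism (strain Wistar) for inhibition, with Rattus norvegicus as the target, read by paw edema, with stated times of 30 min and 3 h, at a dose of 200 mg/kg by the oral route (a lower number here means less inhibition, a higher number more inhibition at the dose given (going by the name of the read-out)), compound 2 gives 50%, the higher of the two numbers, though its gap to compound 1 lies within the scatter, so no order between the two can be claimed. Compound 3, `O=C(O)c1cc(-n2c(-c3ccc([N+](=O)[O-])cc3)cc3c2CCCC3)ccc1O`, has not been measured. It differs from compound 2 in one place: 4-nitrophenyl in place of 2-methoxyphenyl on an aromatic carbon. Among the measured compounds shown here, no step between two measured compounds bears on this change, so the size and direction of its effect are unknown from these data. For the measured compounds named here, with only two measured compounds close to each other, the step from compound 2 to compound 3 is expected to be small, a number 5 percentage points lower from compound 2 to compound 3 (within the scatter), not beyond the scatter. Compound 3 is estimated at 45%, with a range of 25% to 65%.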

Compound 3, a percentage reported as inhibition, in the whole organism at one dose (the size of the read-out at that dose, not a potency): 30%
Compound 3: the middle estimate sits 15 percentage points above what was measured; low and high end bracket the measured number.
By their numbers in this assay, from the lowest: compounds 3, 1 and 2 (each within the scatter of the next, the first and the last beyond it).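

In this assay, 4-nitrophenyl in place of 2-methoxyphenyl on this aromatic carbon, next to the ring nitrogen, gives a number 20 percentage points lower from compound 2 to compound 3 (beyond the scatter) on an otherwise unchanged compound. The group held at this position therefore matters to the read-out at this dose, which compounds 1 and 2 could not show. Nothing at hand accounts for the step. The compounds shown do not separate the nitro group from the change of place on the phenyl ring; 4-methoxyphenyl or 2-nitrophenyl on this carbon would do so. Going by these compounds, how 4-aminophenyl reads here also stays open.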